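The source may report more compounds than this note shows. Statements on the series, on what has been measured and on what is new or still open speak of the compounds shown alone.

Measured compounds and compound to be measured:
- Compound 1: `CCC(=O)N(c1cccc(Cl)c1)C1CCCC1N(C)C`, 0.2 mg/kg
- Compound 2: `CCC(=O)N(c1ccc(F)c(Cl)c1)C1CCCC1N(C)C`, 2 mg/kg
- Compound 3: `CCC(=O)N(c1cc(Cl)cc(Cl)c1)C1CCCC1N(C)C`, not yet measured

For the measured compounds named here, in a functional assay on the whole organism for antagonist activity, with Mus musculus as the target (on this read-out lower numbers stand for an effect already at smaller amounts and higher numbers for an effect only at larger amounts of compound), compound 1 gives 0.2 mg/kg, the lower of the two numbers so far, while compound 2 gives 2 mg/kg. Compound 1 therefore has the better starting position, and any added group has room to raise its number.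

The move to compound 3 is chloro in place of hydrogen on an aromatic carbon. Going by the values given here, only one measured step bears on this change. It is a 10-fold higher number from compound 1 to compound 2 (1.00 log units; beyond the scatter), which is fluoro in place of hydrogen on an aromatic carbon and lies beyond the scatter. That single case involves a different halogen at a different place, so it suggests a direction more firmly than a size. A higher number in this assay is expected, probably by less than the step to compound 2, although the data cannot confirm this. The estimated change is a 3.0-fold higher number from compound 1 to compound 3 (0.48 log units; beyond the scatter). For compound 3 the expected value is 0.6 mg/kg, within an estimated range of 0.1 mg/kg to 3 mg/kg.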

Compound 3, dose for half-maximal effect: 5 mg/kg
Compound 3: the middle estimate sits 8.3-fold (0.92 log units) below what was measured; the measured number lies above the stated range.
By their numbers in this assay, from the lowest: compound 1; then compound 2; then compound 3.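

In this assay, a second chloro on an aromatic carbon, meta to a chloro group, moves the number sharply the wrong way, with a 25-fold higher number from compound 1 to compound 3 (1.40 log units; beyond the scatter) as the step. This shows that the loss seen earlier with fluoro, a 10-fold higher number from compound 1 to compound 2 (1.00 log units; beyond the scatter), is not a single event: both halogens added to compound 1 raise the number beyond the scatter, although they differ in kind and in place, so a hydrogen at these two carbons has so far given the lowest number. These two steps cannot separate the effect of the halogen from the effect of its place on the ring, and nothing measured here explains why the number rises. On these data alone, it remains open whether the rise comes with chloro in particular or with any group on this carbon, such as fluoro, methyl, methoxy or an amine. It is also unknown whether changes elsewhere on the core of compound 1, such as a longer chain on the carbonyl, could bring the number lower still.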